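The source may hold more compounds than are shown below. What is called first, only, known or untested is meant among the compounds shown, and "the series" means these compounds.

In a functional assay on MCF7 cells (Homo sapiens) for inhibition, read by fluorescence, with a stated time of 72 h (a higher number here means a weaker inhibitor, a lower number a stronger inhibitor), compound 1 `Cn1cnc2c(NC(=N)N)nc(N)nc21` reaches only a limit of the assay, > 100000 nM. Compound 2 `CC(C)n1cnc2c(NC(=N)N)nc(NCCO)nc21` gives 12400 nM in this assay. Compound 3 `CC(C)n1cnc2c(NC(=N)N)nc(NCCCCCCO)nc21` gives 5200 nM, the lower of the two actual numbers. Compound 4 `CC[C@@H](CO)Nc1nc(NC(=N)N)c2ncn(C(C)C)c2n1` carries 1-(hydroxymethyl)propyl in place of the 6-hydroxyhexyl of compound 3, on a nitrogen on an aromatic ring (1-(hydroxymethyl)propyl in place of 6-hydroxyhexyl on a nitrogen on an aromatic ring). The entering group is the smaller one and has one defined stereocentre. Among the measured compounds shown here, only one measured step bears on this change: a 2.4-fold lower number from compound 2 to compound 3 (0.38 log units; beyond the scatter). That step lengthened the chain on the same nitrogen, so a shorter group may be expected to give back some of that gain. For the measured compounds named here, no measured compound carries a stereocentre in this group, which leaves the forecast loose. The expected change in this assay is modest and toward a higher number, a 2.1-fold higher number from compound 3 to compound 4 (0.33 log units; beyond the scatter). The estimate for compound 4 is 11000 nM, with an expected range of 4000 nM to 30000 nM.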

Compound 4, half-maximal inhibitory concentration: 1600 nM
For compound 4 the middle estimate is 6.9-fold (0.84 log units) above the measured one; the measured number lies below the stated range.
By their numbers in this assay, from the lowest: compound 4; then compound 3; then compound 2. At a limit, above all of these: compound 1.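

In this assay the longer chain had given a 2.4-fold lower number from compound 2 to compound 3 (0.38 log units; beyond the scatter) and yet the smaller 1-(hydroxymethyl)propyl goes further still, with a 3.3-fold lower number from compound 3 to compound 4 (0.51 log units; beyond the scatter) as the result. Chain length alone therefore does not order the compounds at this nitrogen, and compound 4 is the one that goes against a reading in which longer means lower. Ethyl in place of hydrogen on the saturated chain carbon bound to the nitrogen gives a 7.8-fold lower number from compound 2 to compound 4 (0.89 log units; beyond the scatter) and so a group on that carbon also moves the number.

The compounds shown leave open what the opposite stereoisomer of this group, or an isopropyl in place of its ethyl, would give. Nothing shown gives a reason for these steps.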